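This account rests on a few compounds, and the source may have more. Where it says the series, first, only, none or still open, it means among the compounds named here.

Going by the values given here, compound 1 `CNC(=O)N1CCCc2ccc(NC(=O)c3ccc(-c4ccn(C)n4)cc3)cc21` gives 97% in a functional assay on MV4-11 cells (Homo sapiens) for antiproliferative activity, with a stated time of 6 days, tested at 6.25 uM (a higher number here means a stronger effect of the compound at the concentration tested, a lower number a weaker effect), the highest of the three numbers known. Compound 3 `CNC(=O)N1CCCc2ccc(NC(=O)c3cccc(-c4ccn(C(C)=O)n4)c3)cc21` gives 87.6%, within the scatter of compound 1, while compound 2 `CNC(=O)N1CCCc2ccc(NC(=O)c3cccc(-c4cnn(S(C)(=O)=O)c4)c3)cc21` gives 18%, well below it. Compound 4 `CNC(=O)N1CCCc2ccc(NC(=O)c3ccc(-c4cnn(S(C)(=O)=O)c4)cc3)cc21` differs from compound 1 by 1-(methylsulfonyl)-1H-pyrazol-4-yl in place of 1-methyl-1H-pyrazol-3-yl on an aromatic carbon. Among the compounds with values here, the only measured step that bears on this change is a number 69.6 percentage points higher from compound 2 to compound 3 (beyond the scatter), which runs in the opposite direction and removes the same methylsulfonyl pyrazolyl group, though in a different setting; no step installs that group in a compound like compound 1. The step of a number 52 percentage points lower from compound 1 to compound 4 (beyond the scatter) is therefore expected to be a loss, large but uncertain in size. Compound 4 is estimated at 45%, between 15% and 85%.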

Compound 4, a percentage reported as inhibition, at one concentration (the size of the read-out at that concentration, not a potency): 40.2%
Compound 4: middle estimate off by 4.8 percentage points, on the high side, within the range that was stated.
By their numbers in this assay, from the lowest: compound 2; then compound 4; then compounds 3 and 1 (each within the scatter of the next).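

In this assay, going by these compounds alone, putting 1-(methylsulfonyl)-1H-pyrazol-4-yl in place of 1-methyl-1H-pyrazol-3-yl para to a large group gives a number 56.8 percentage points lower from compound 1 to compound 4 (beyond the scatter), the first direct reading of this change at this position. It shows that the low number seen with this group in compound 2 is not confined to that setting. No measurement at hand accounts for the loss.

From the compounds shown here alone, the change replaces methyl with methylsulfonyl and 3-yl with 4-yl at once, so the share of each remains open. A 1-methyl-1H-pyrazol-4-yl group at this position would separate the two.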